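Changing the Aryl Group on the Sulfonyl Sulfur

This account rests on a few compounds, and the source may have more. Where it says the series, first, only, none or still open, it means among the compounds named here.

Measured in an assay on MDA-MB-231 cells for displacement of a labelled ligand from C-X-C chemokine receptor type 4 (Homo sapiens), read by fluorescence and microscopy, with stated times of 10 min and 30 min; on this read-out lower numbers stand for an effect already at smaller amounts and higher numbers for an effect only at larger amounts of compound:
compound 1, `O=C(NCc1ccc(CNS(=O)(=O)c2ccccc2F)cc1)c1cccnc1`, gives 100 nM
compound 2, `COc1ccccc1C(=O)NCc1ccc(CNS(=O)(=O)c2cccc3ccccc23)cc1`, gives > 1000 nM, a limit of the assay
compound 3, `COc1ccccc1C(=O)NCc1ccc(CNS(=O)(=O)c2ccccc2F)cc1`, gives 1 nM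

Compound 3 has the lowest number of the two numbers shown; its nearest neighbour is compound 1, with a 100-fold lower number from compound 1 to compound 3 (2.00 log units; beyond the scatter). Compound 2 shows only (the limit of > 1000 nM in this assay, at which 1 of the 3 values shown sits). The change from compound 2 to compound 3 is an at least 1000-fold lower number from compound 2 to compound 3 (3.00 log units; beyond the scatter).

Compound 4, `COc1ccccc1C(=O)NCc1ccc(CNS(=O)(=O)c2ccc([N+](=O)[O-])cc2)cc1`, differs from compound 3 in one place: 4-nitrophenyl in place of 2-fluorophenyl on a sulfonyl sulfur. The step that bears directly on it is the one on the same sulfonyl sulfur, an at least 1000-fold lower number from compound 2 to compound 3 (3.00 log units; beyond the scatter), which shows that the group there can move the number by a large amount. The step of a 100-fold lower number from compound 1 to compound 3 (2.00 log units; beyond the scatter) concerns another place and bears less. Among the compounds with values here, since 4-nitrophenyl is a new group at this position, the size of the step is uncertain, but the one known change there went strongly upward, so compound 4 is expected to give a higher number than compound 3, estimated as a 30-fold higher number from compound 3 to compound 4 (1.48 log units; beyond the scatter). Compound 4 is therefore estimated at 30 nM, with a range from 3 nM to 1000 nM.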

Compound 4, effective concentration (reported as EC, without a stated level of effect): 100 nM
Estimate against measurement, compound 4: 3.3-fold (0.52 log units) below; measured number inside the range.
By their numbers in this assay, from the lowest: compound 3; then compounds 1 and 4 (each within the scatter of the next). At a limit, above all of these: compound 2.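

At the sulfonyl sulfur, a 100-fold higher number from compound 3 to compound 4 (2.00 log units; beyond the scatter) in this assay shows that the low number of compound 3 does not depend on the comparison with naphthalen-1-yl alone, since 4-nitrophenyl, a single six-membered aromatic ring like 2-fluorophenyl, also gives up much of it. The same position also separates 4-nitrophenyl from naphthalen-1-yl, with an at least 10-fold lower number from compound 2 to compound 4 (1.00 log units; beyond the scatter), so the three groups give three distinct results rather than a simple split into good and bad. The value of compound 2 is a limit of the assay, so this last step is only a minimum: the limit of > 1000 nM in this assay, at which 1 of the 4 values shown sits.

Because 2-fluorophenyl and 4-nitrophenyl differ in both the substituent and its place on the ring, the compounds shown cannot separate these two changes. Going by these compounds, how 4-fluorophenyl, 2-nitrophenyl, unsubstituted phenyl or a simple alkyl chain on the sulfonyl sulfur would fare remains open.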